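A few compounds are considered here, and "the series" means these few. Any claim that something is new, unique, unknown or untested is made for them only; others in the source may bear on it.

Compound 3 `CN(CCCNS(=O)(=O)c1cc(C(F)(F)F)cc(C(F)(F)F)c1)Cc1ccccc1` gives the highest number of the three measured in a functional assay on A2780 cells (Homo sapiens) for inhibition, read by MTT assay, with a stated time of 72 h (on this read-out higher numbers stand for weaker inhibition of growth and lower numbers for stronger inhibition of growth), at 28000 nM. Compound 1 `O=S(=O)(NCCCNCc1ccc(Cl)c(C(F)(F)F)c1)c1cc(C(F)(F)F)cc(C(F)(F)F)c1` gives 5900 nM in this assay, and compound 2 `O=S(=O)(NCCCNCC1COc2ccccc2O1)c1cc(C(F)(F)F)cc(C(F)(F)F)c1` gives 1500 nM; both lie well below compound 3, and each of those gaps is beyond the scatter. Compound 4 `O=S(=O)(NCCCNCc1ccccc1)c1cc(C(F)(F)F)cc(C(F)(F)F)c1` has not yet been measured. It differs from compound 3 in a single place: hydrogen in place of methyl on an amine nitrogen. Among the measured compounds shown here, no measured pair isolates this change. For the measured compounds named here, the only measured step, a 3.9-fold lower number from compound 1 to compound 2 (0.59 log units; beyond the scatter), swaps the group on a saturated chain carbon bound to the amine nitrogen and says nothing about the substituent on that nitrogen itself. What the numbers do show is that compound 1 and compound 2, which both carry a hydrogen on that nitrogen, sit far below compound 3 with its methyl, although their groups on the chain carbon also differ from the benzyl of compound 4, so the comparison is not clean. On that limited ground a drop is expected, a 3.5-fold lower number from compound 3 to compound 4 (0.54 log units; beyond the scatter), with a wide uncertainty about its size. Compound 4 is therefore expected to give about 8000 nM in this assay, within a likely range from 2500 nM to 25000 nM.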

Compound 4, concentration for 50% growth inhibition: 4900 nM
The estimate for compound 4 lay 1.6-fold (0.21 log units) above the measured number; measured number inside the range.
By their numbers in this assay, from the lowest: compound 2; then compounds 4 and 1 (each within the scatter of the next); then compound 3.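

In this assay, hydrogen in place of methyl on an amine nitrogen can now be read as a single change, and it gives a 5.7-fold lower number from compound 3 to compound 4 (0.76 log units; beyond the scatter); on this benzyl-bearing pair, then, the methyl goes with weaker inhibition of growth. Among the compounds shown here, compound 4 also links the earlier compounds, which keep the same hydrogen on that nitrogen, so the group on the saturated chain carbon bound to it can be compared directly: phenyl in place of 2,3-dihydro-1,4-benzodioxin-2-yl gives a 3.3-fold higher number from compound 2 to compound 4 (0.51 log units; beyond the scatter), whereas phenyl in place of 4-chloro-3-(trifluoromethyl)phenyl gives a 1.2-fold lower number from compound 1 to compound 4 (0.08 log units; within the scatter) and so shows no readable difference between those two groups. No measurement is at hand that explains any of these steps.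

Going by these compounds, the methyl step rests on one pair of compounds, and whether it holds with the 2,3-dihydro-1,4-benzodioxin-2-yl group of compound 2 remains open. Also open, on these data alone, is how an ethyl or an acetyl group on that same nitrogen would compare with hydrogen and methyl.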